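This account rests on a few compounds, and the source may have more. Where it says the series, first, only, none or still open, it means among the compounds named here.

The three compounds share one core and differ only in the halogens carried on the ring joined to the hydrazine. Compound 1, `CC(=O)Nc1ccc(S(=O)(=O)NNc2ccc(Cl)cc2)cc1`, carries a single chloro group; in an assay on HeLa cells for inhibition of Indoleamine 2,3-dioxygenase 1 (Homo sapiens), read by spectrophotometry, with a stated time of 24 h (a higher number here means that more compound is needed for the effect, a lower number that less compound is needed), compound 1 gives 142 nM. Compound 2, `CC(=O)Nc1ccc(S(=O)(=O)NNc2ccc(F)c(Cl)c2)cc1`, carries a fluoro group and a chloro group; in this assay compound 2 gives 2590 nM. Compound 3, `CC(=O)Nc1ccc(S(=O)(=O)NNc2ccc(Cl)c(F)c2)cc1`, carries the same two halogens with their places exchanged; in this assay compound 3 gives 84 nM. On these numbers compound 3 and compound 1 lie within the usual scatter of each other, as shown by the step of a 1.7-fold lower number from compound 1 to compound 3 (0.23 log units; within the scatter), while compound 2 sits well apart from both. Compound 4, `CC(=O)Nc1ccc(S(=O)(=O)NNc2ccc(Cl)c(Cl)c2)cc1`, arises from compound 3 by a single change: chloro in place of fluoro on an aromatic carbon. Within the data shown here, no measured pair shows this exact exchange of one halogen for another, so the only guide is the single-change step already seen, a 1.7-fold lower number from compound 1 to compound 3 (0.23 log units; within the scatter), which was small. A small change in this assay is therefore expected, without a clear direction. The estimate for compound 4 is 100 nM, with a range from 30 nM to 350 nM; the expected step is a 1.2-fold higher number from compound 3 to compound 4 (0.08 log units; within the scatter), within the scatter.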

Compound 4, half-maximal effective concentration: 350 nM
Compound 4: middle estimate off by 3.5-fold (0.54 log units), on the low side; low and high end bracket the measured number.
By their numbers in this assay, from the lowest: compounds 3 and 1 (each within the scatter of the next); then compound 4; then compound 2.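

At this place, an aromatic carbon ortho to a chloro group, the identity of the halogen now matters in this assay: the exchange of fluoro for chloro gives a 4.2-fold higher number from compound 3 to compound 4 (0.62 log units; beyond the scatter), and chloro in place of hydrogen gives a 2.5-fold higher number from compound 1 to compound 4 (0.39 log units; beyond the scatter), both beyond the scatter, whereas fluoro in place of hydrogen at this same carbon gave only a 1.7-fold lower number from compound 1 to compound 3 (0.23 log units; within the scatter), within the scatter. The same kind of exchange, chloro in place of fluoro, made on the other halogen-bearing carbon runs the opposite way, with a 7.4-fold lower number from compound 2 to compound 4 (0.87 log units; beyond the scatter), so the direction of this change depends on where it is made among these compounds. The data shown offer no independent measurement that accounts for either direction.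

The compounds shown leave open how a bromo, methyl or methoxy group would compare with hydrogen, fluoro and chloro on this carbon. They also leave open how an amine or a carboxylic acid at the same place would behave in this assay.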